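A few compounds are considered here, and "the series" means these few. Any claim that something is new, unique, unknown or untested is made for them only; others in the source may bear on it.

In a functional assay on A2780 cells (Homo sapiens) for cytotoxicity, read by MTT assay, with a stated time of 68 h (on this read-out higher numbers stand for weaker inhibition and lower numbers for stronger inhibition), three compounds that share one core have been measured. Compound 1 (`O=C(/C=C/c1cccc(OCc2ccccc2)c1)c1ccc([N+](=O)[O-])cc1`) gives 56400 nM, compound 2 (`O=C(/C=C/c1cccc(OCc2ccccc2)c1)c1ccc(Cl)cc1Cl`) gives 21400 nM and compound 3 (`O=C(/C=C/c1cccc(OCc2ccccc2)c1)c1ccc(Br)cc1`) gives 1800 nM. Compound 3 therefore has the lowest number of the three and is the strongest inhibitor so far.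

The next compound, compound 4 (`O=C(/C=C/c1cccc(OCc2ccccc2)c1)c1ccc(Cl)c(Cl)c1Cl`), has not yet been measured. It carries one change: 2,3,4-trichlorophenyl in place of 4-bromophenyl on a carbonyl carbon, with 2,3,4-trichlorophenyl in place of 4-bromophenyl on a carbonyl carbon.

Among the compounds with values here, the closest guide is compound 2, the only measured compound with chlorines on this ring, and the data show a 12-fold lower number from compound 2 to compound 3 (1.08 log units; beyond the scatter), a large step. The other steps add context: a 31-fold lower number from compound 1 to compound 3 (1.50 log units; beyond the scatter) is also large, while a 2.6-fold lower number from compound 1 to compound 2 (0.42 log units; beyond the scatter) is modest. Within the data shown here, compound 4 swaps the bromophenyl group for a chlorinated ring, roughly reversing the step to compound 3, although no trichlorophenyl compound has been measured.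

A large move towards a higher number is therefore expected, an estimated 8.3-fold higher number from compound 3 to compound 4 (0.92 log units; beyond the scatter). The expected value for compound 4 is 15000 nM, with an estimated range of 4000 nM to 50000 nM.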

Compound 4, half-maximal inhibitory concentration: 1500 nM
The estimate for compound 4 lay 10-fold (1.00 log units) above the measured number; the whole stated range lies above it.
By their numbers in this assay, from the lowest: compounds 4 and 3 (each within the scatter of the next); then compound 2; then compound 1.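

A chlorinated ring on this carbonyl carbon does not have to give a weak number: in this assay, 2,3,4-trichlorophenyl and 4-bromophenyl stand level (a 1.2-fold lower number from compound 3 to compound 4 (0.08 log units; within the scatter)). The ring's chlorine pattern matters greatly, since chloro in place of hydrogen on an aromatic carbon gives a large step (a 14-fold lower number from compound 2 to compound 4 (1.15 log units; beyond the scatter)). 2,3,4-Trichlorophenyl in place of 4-nitrophenyl also gives a large step (a 38-fold lower number from compound 1 to compound 4 (1.58 log units; beyond the scatter)), so two quite different rings now sit far below the nitro compound.

Nothing available here explains why these rings differ so widely. The compounds shown also leave open how this position would respond to a ring carrying an amine, a carboxylic acid or a methoxy group, or to a plain phenyl ring with no group on it.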